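Shortening the Ether Chain on Compound 2

The compounds below may be only part of what the source reports. "The series", "measured", "known", "first", "only" and "open" are said of these compounds alone.

Compound 2 `N#Cc1c(N)nc(SCc2ncc[nH]2)c(C#N)c1-c1ccc(OCC2CC2)cc1` gives 235 nM in an assay on CHO cells for displacement of a labelled ligand from adenosine receptor A1 (Homo sapiens), read by scintillation counting, with a stated time of 90 min (a lower number here means a stronger inhibitor, a higher number a weaker inhibitor), the higher of the two numbers seen so far. Compound 1 `CCOc1ccc(-c2c(C#N)c(N)nc(SCc3ccn[nH]3)c2C#N)cc1` gives 21 nM in this assay, but it differs from compound 2 in two places, so the gap between them cannot be laid at one change. Compound 3 `CCOc1ccc(-c2c(C#N)c(N)nc(SCc3ncc[nH]3)c2C#N)cc1` differs from compound 2 in one place: methyl in place of cyclopropyl on a saturated chain carbon bound to an oxygen on an aromatic ring. Within the data shown here, no single-change step is known here, so the expected step from compound 2 to compound 3 is modest, a 1.6-fold lower number from compound 2 to compound 3 (0.19 log units; within the scatter), with a lower number slightly favoured. Compound 3 is estimated at 150 nM, within 50 nM to 500 nM.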

Compound 3, inhibition constant: 8.2 nM
The estimate for compound 3 lay 18-fold (1.26 log units) above the measured number, outside the stated range (below it).
By their numbers in this assay, from the lowest: compound 3; then compound 1; then compound 2.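

In this assay, going from cyclopropylmethoxy to ethoxy gives a 29-fold lower number from compound 2 to compound 3 (1.46 log units; beyond the scatter), so this ether position responds strongly to a small change in the group at the end of the chain. The change of 1H-pyrazol-5-yl to 1H-imidazol-2-yl on the sulfur-bound carbon gives a 2.6-fold lower number from compound 1 to compound 3 (0.41 log units; beyond the scatter), a modest step beside that large one. No measurement available here explains why methyl outperforms cyclopropyl at this position.

From the compounds shown here alone, whether methoxy, the shorter ether, or propoxy, a longer chain, would give a lower or higher number remains open. So does the effect of an amine at the end of the chain.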